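Fluoro added to the trifluoromethylphenyl ring of compound 3

A few compounds are considered here, and "the series" means these few. Any claim that something is new, unique, unknown or untested is made for them only; others in the source may bear on it.

Three compounds of the series have been run in a functional assay on CHO cells for antagonist activity at Orexin/Hypocretin receptor type 1 (Homo sapiens), read by FLIPR and calcium flux; a lower number here means a stronger inhibitor, a higher number a weaker inhibitor. Compound 1 `CCc1nc(Cl)c2n1CCN([C@@H](C(=O)NC)c1ccccc1)[C@H]2COc1cccc(C(F)(F)F)c1` carries an oxygen link to its trifluoromethylphenyl ring and gives 312 nM. Compound 2 `CCc1nc(Cl)c2n1CCN([C@@H](C(=O)NC)c1ccccc1)[C@H]2CCc1cc(F)c(C(F)(F)F)cc1F`, with a two-carbon link to a ring bearing two fluoro groups and a trifluoromethyl, gives 32 nM. Compound 3 `CNC(=O)[C@@H](c1ccccc1)N1CCn2c(C3CC3)nc(Cl)c2[C@@H]1CCc1ccc(C(F)(F)F)cc1`, with the two-carbon link to an unsubstituted trifluoromethylphenyl ring and a cyclopropyl on the shared core, gives 30 nM. Compound 3 shows the lowest number of the three; its value and that of compound 2 lie within the scatter of each other, while the gap to compound 1 lies beyond it.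

Compound 4 `CNC(=O)[C@@H](c1ccccc1)N1CCn2c(C3CC3)nc(Cl)c2[C@@H]1CCc1ccc(C(F)(F)F)c(F)c1` is the next step from compound 3: fluoro in place of hydrogen on an aromatic carbon. Within the data shown here, no pair already measured isolates exactly this change. The closest guide is compound 2, whose fluoro-bearing ring gives 32 nM, within the scatter of compound 3, so the step from compound 3 to compound 4 is expected to be small, with no clear direction beyond the scatter, estimated as no change at the digits printed from compound 3 to compound 4 (within the scatter). Compound 4 is therefore expected to give about 30 nM in this assay, with a range from 12 nM to 75 nM.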

Compound 4, half-maximal inhibitory concentration: 53 nM
Beside the measured number, compound 4's estimate is 1.8-fold (0.25 log units) below it, and the stated range covers the measured number.
By their numbers in this assay, from the lowest: compounds 3, 2 and 4 (each within the scatter of the next); then compound 1.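

In this assay, the change from 4-(trifluoromethyl)phenyl to 3-fluoro-4-(trifluoromethyl)phenyl gives the series its first reading of a single change, a 1.8-fold higher number from compound 3 to compound 4 (0.25 log units; within the scatter), with the rest of the structure held constant. Among these compounds, the aromatic carbon ortho to the trifluoromethyl group and meta to a large group therefore accepts fluoro in place of hydrogen without a step beyond the scatter, something the earlier compounds could not show because each pair among them differs in more than one place. No measurement at hand accounts for the size of this step, and this single pair supports no rule for other substituents or other positions on the ring.

On these data alone, whether a larger group on the same aromatic carbon, such as methoxy, nitrile or an amine, would also stay within the scatter remains open, so the limit of what this position accepts is unknown. The separate contributions of the ethyl and cyclopropyl groups on the shared core, of the oxygen link and of the two-carbon link cannot be read from the compounds shown, and a longer chain to the aromatic ring remains an open question.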